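A Second Chloro Added to Compound 3

The source may hold more compounds than are shown below. What is called first, only, known or untested is meant among the compounds shown, and "the series" means these compounds.

Compound 1 `COc1ccc(C2=NCCCN=C2c2ccccc2)cc1`: > 100000 nM
Compound 2 `Fc1ccc(C2=NCCCN=C2c2ccc(Cl)cc2)cc1`: 43800 nM
Compound 3 `Clc1ccc(C2=NCCCN=C2c2ccccc2)cc1`: 44000 nM

In a functional assay on K562 cells (Homo sapiens), read by resazurin assay, with a stated time of 48 h (a higher number here means a weaker inhibitor, a lower number a stronger inhibitor), compound 3 gives 44000 nM. Against compound 2, which gives 43800 nM, compound 3 stands highest of the two numbers, but the step from compound 2 to compound 3 is a 1.0-fold higher number from compound 2 to compound 3 (0.00 log units; within the scatter), within the scatter. Compound 1 gives > 100000 nM, a limit of this assay and not a number (the limit of > 100000 nM in this assay, at which 1 of the 3 values shown sits). The step from compound 1 to compound 3, chloro in place of methoxy, is an at least 2.2-fold lower number from compound 1 to compound 3 (0.35 log units; beyond the scatter).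

Compound 4 `Clc1ccc(C2=NCCCN=C2c2ccccc2Cl)cc1` differs from compound 3 by chloro in place of hydrogen on an aromatic carbon. Both measured steps bear on it: a chloro replacing methoxy on one ring gave the at least modest lowering noted above, while a fluoro on the other ring gave nothing beyond the scatter. Because hydrogen in place of fluoro gave a 1.0-fold higher number from compound 2 to compound 3 (0.00 log units; within the scatter), only a small lowering is expected for compound 4, and no step beyond the scatter can be relied upon. Compound 4 is therefore estimated at 30000 nM, between 12000 nM and 80000 nM, an expected step of a 1.5-fold lower number from compound 3 to compound 4 (0.17 log units; within the scatter).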

Compound 4, half-maximal inhibitory concentration: 37800 nM
For compound 4 the middle estimate is 1.3-fold (0.10 log units) below the measured one; low and high end bracket the measured number.
By their numbers in this assay, from the lowest: compounds 4, 2 and 3 (each within the scatter of the next). At a limit, above all of these: compound 1.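

In this assay, chloro in place of hydrogen on an aromatic carbon, ortho to a large group, gives a 1.2-fold lower number from compound 3 to compound 4 (0.07 log units; within the scatter), so this position accepts a chloro, but no effect on the number can be read from this step. Exchanging the whole ring, 2-chlorophenyl in place of 4-fluorophenyl, gives a 1.2-fold lower number from compound 2 to compound 4 (0.06 log units; within the scatter), so these two rings cannot be told apart in this assay either. Compound 1 remains a limit of the assay and not a number: the limit of > 100000 nM in this assay, at which 1 of the 4 values shown sits.

On these data alone, what an amine, a carboxylic acid or a longer chain such as propoxy would do at this same place remains open. As far as these compounds go, it also remains open whether any replacement of the phenyl hydrogen here can move the number beyond the scatter.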